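The compounds below may be only part of what the source reports. "The series", "measured", "known", "first", "only" and "open" are said of these compounds alone.

Four compounds share one core and differ only in the group carried on a saturated chain carbon bound to an aromatic carbon. In an ADME assay on the whole organism for pharmacokinetics, with Rattus norvegicus as the target, with a stated time of 6 h, at a dose of 10 mg/kg by the oral route (on this read-out higher numbers stand for higher exposure at the dose given and lower numbers for lower exposure), compound 1 `Cc1cn2c(-c3cn[nH]c3)cnc2c(Nc2cc(Cn3cccn3)ns2)n1` gives "not determined" (no result reported), that is, no result is reported. Compound 2 `Cc1cn2c(-c3cn[nH]c3)cnc2c(Nc2cc(Cn3cccc(C)c3=O)ns2)n1` likewise gives "not determined" (no result reported) in this assay, so compound 2 stands nowhere on the scale of exposure: it is one of two compounds without a single number, the other being compound 1. Within the data shown here, the one measured member of the set, compound 3 `Cc1cn2c(-c3cn[nH]c3)cnc2c(Nc2cc(Cc3ncccc3F)ns2)n1`, gives 569 ng.h/mL in this assay, and that single value is the only anchor for any expectation.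

Compound 4 `Cc1cn2c(-c3cn[nH]c3)cnc2c(Nc2cc(Cc3cccc(F)n3)ns2)n1` is not yet measured. It differs from compound 2 in one place: a group of 7 heavy atoms (5 carbon, 1 nitrogen, 1 fluorine; one six-membered aromatic ring with 1 hetero atom) in place of a group of 8 heavy atoms (6 carbon, 1 nitrogen, 1 oxygen; one six-membered aromatic ring with 1 hetero atom), on a saturated chain carbon bound to an aromatic carbon. Compound 2 has no number, so the change to compound 4 cannot be sized as a step in this assay, and the expectation must rest on compound 3 alone. Compound 3 also carries a six-membered aromatic ring with one hetero atom and one fluorine on the same chain carbon, so its value of 569 ng.h/mL is taken as the nearest guide, with no move beyond the usual scatter expected between them. Compound 4 is therefore expected to give about 500 ng.h/mL in this assay, with a range from 150 ng.h/mL to 1600 ng.h/mL.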

Compound 4, area under the concentration-time curve: 2970 ng.h/mL
Estimate against measurement, compound 4: 5.9-fold (0.77 log units) below; measured number outside the range, above it.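

In this assay, replacing 3-fluoropyridin-2-yl with 6-fluoropyridin-2-yl on a saturated chain carbon bound to an aromatic carbon gives a 5.2-fold higher number from compound 3 to compound 4 (0.72 log units; beyond the scatter), a step beyond the usual scatter. Both groups have the same atoms and differ only in the numbers in their names, so this position responds to how those atoms are arranged and not only to which atoms are present, something a single measured compound could not reveal. Nothing available here explains why the number rises between these two compounds.

Steps involving compound 1 or compound 2 cannot be read, so this single pair is the only comparison available, and it gives no view of how the groups in those two compounds would rank against the fluoropyridines. It also leaves open what the fluorine itself contributes, which a plain pyridin-2-yl group would address, and whether another atom in its place, as in 6-chloropyridin-2-yl, would give a similar number.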